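Changing the group on the chain carbon of compound 3

The source may hold more compounds than are shown below. What is called first, only, known or untested is meant among the compounds shown, and "the series" means these compounds.

Of the compounds shown here, three sharing one core have been measured in an assay on isolated protein (Oryctolagus cuniculus) with Thromboxane-A synthase (Homo sapiens) as the target, tested at 1 uM; a higher number here means more inhibition at the concentration tested (going by the name of the read-out), a lower number less inhibition. Compound 1 `CCCCCCCCn1nc(-c2cccnc2)c2ccccc2c1=O` gives 99%; compound 2 `O=c1c2ccccc2c(-c2cccnc2)nn1Cc1ccccc1` gives 97%; compound 3 `O=c1c2ccccc2c(-c2cccnc2)nn1Cc1cccc(Cl)c1` gives 95%. The steps between them are small: a number 2 percentage points lower from compound 1 to compound 2 (within the scatter), a number 4 percentage points lower from compound 1 to compound 3 (within the scatter) and a number 2 percentage points lower from compound 2 to compound 3 (within the scatter). Compound 3 thus holds the lowest of the three numbers, yet its distance to each of the other two lies within the scatter, so the three stand together.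

Compound 4 `O=c1c2ccccc2c(-c2cccnc2)nn1CCSc1nccs1` has not yet been measured. It differs from compound 3 in one place: ((1,3-thiazol-2-yl)sulfanyl)methyl in place of 3-chlorophenyl on a saturated chain carbon bound to an aromatic nitrogen. The measured steps that bear on this change are the two that replace the group on the same saturated chain carbon bound to an aromatic nitrogen, a number 4 percentage points lower from compound 1 to compound 3 (within the scatter) and a number 2 percentage points lower from compound 1 to compound 2 (within the scatter), both within the scatter; among the compounds shown, a heptyl, a phenyl and a 3-chlorophenyl at that place all leave the inhibition high. Among the compounds with values here, no measured step involves a ((1,3-thiazol-2-yl)sulfanyl)methyl group, so the expectation rests on this analogy alone. Compound 4 is therefore expected to show a step of a number 1 percentage points lower from compound 3 to compound 4 (within the scatter) that does not go beyond the scatter. The estimate for compound 4 is 94%. The range expected for compound 4 runs from 82% to 100%.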

Compound 4, a percentage reported as inhibition, at one concentration (the size of the read-out at that concentration, not a potency): 97%
Compound 4: middle estimate off by 3 percentage points, on the low side; measured number inside the range.
By their numbers in this assay, from the lowest: compounds 3, 2, 4 and 1 (each within the scatter of the next).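

In this assay the place on a saturated chain carbon bound to an aromatic nitrogen also takes a group of a different build: ((1,3-thiazol-2-yl)sulfanyl)methyl brings one five-membered aromatic ring with 2 hetero atoms and 3 hydrogen-bond acceptors where 3-chlorophenyl has one six-membered aromatic ring of carbon only and none, and the exchange gives a number 2 percentage points higher from compound 3 to compound 4 (within the scatter) in this reading. The same holds against the other two groups, with phenyl replaced to give no change at the digits printed from compound 2 to compound 4 (within the scatter) and, one carbon further along the chain, hexyl replaced by (1,3-thiazol-2-yl)sulfanyl to give a number 2 percentage points lower from compound 1 to compound 4 (within the scatter) as the printed step. A plain chain, two benzyl groups and a sulfur-linked thiazole thus all stand together at this place, and nothing at hand explains why they read alike.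

On these data alone, none of the four groups moves the number beyond the scatter, so it stays open which group at this place would lower the inhibition, for instance a carboxylic acid or a primary amine at the end of the chain. As far as these compounds go, it also stays open whether the four would still stand together at a lower tested concentration, since a single concentration gives the size of the read-out and not a potency.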